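This account rests on a few compounds, and the source may have more. Where it says the series, first, only, none or still open, it means among the compounds named here.

Measured so far:
compound 1 `CCO/C(O)=C1\C(COCCNc2n[nH]c(N)n2)=NC(C)=C(C(=O)OC)C1c1cccc(Cl)c1Cl`: 6.31 nM
compound 2 `CCO/C(O)=C1\C(COCCNc2nccnc2Cl)=NC(C)=C(C(=O)OC)C1c1cccc(Cl)c1Cl`: 2.51 nM

In a functional assay (aorta) with Rattus norvegicus as the target (on this read-out higher numbers stand for weaker inhibition and lower numbers for stronger inhibition), compound 1 gives 6.31 nM, the highest of the two numbers. Compound 2 gives 2.51 nM, with a 2.5-fold lower number from compound 1 to compound 2 (0.40 log units; beyond the scatter). Compound 3 `CCO/C(O)=C1\C(COCCNc2n[s+]([O-])nc2N)=NC(C)=C(C(=O)OC)C1c1cccc(Cl)c1Cl` differs from compound 1 by a group of 7 heavy atoms (2 carbon, 3 nitrogen, 1 oxygen, 1 sulfur; one five-membered aromatic ring with 3 hetero atoms) in place of a group of 6 heavy atoms (2 carbon, 4 nitrogen; one five-membered aromatic ring with 3 hetero atoms), on an amine nitrogen. Going by the values given here, the single measured step, from compound 1 to compound 2, replaced the same 5-amino-1H-1,2,4-triazol-3-yl group by a different ring and gave a modest lowering, so it bears on this change only loosely. For compound 3 a step of a 1.3-fold lower number from compound 1 to compound 3 (0.10 log units; within the scatter) is expected, small and close to the scatter. Compound 3 is therefore estimated at 5 nM, between 1.5 nM and 16 nM.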

Compound 3, half-maximal inhibitory concentration: 15.9 nM
Compound 3: the middle estimate sits 3.2-fold (0.50 log units) below what was measured, within the range that was stated.
By their numbers in this assay, from the lowest: compound 2; then compound 1; then compound 3.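

In this assay, exchanging one five-membered aromatic ring with 3 hetero atoms for another on the amine nitrogen gives a 2.5-fold higher number from compound 1 to compound 3 (0.40 log units; beyond the scatter), while the change from the six-membered ring gives a 6.3-fold higher number from compound 2 to compound 3 (0.80 log units; beyond the scatter). This position therefore responds to the identity of the ring, even when ring size and hetero atom count stay the same. Nothing available explains this shift. Still open, on these data alone, is what a plain phenyl ring or an acetyl group on this amine nitrogen would give, and whether the sulfur and oxygen atoms or the ring as a whole govern the number of compound 3.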